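The source may report more compounds than this note shows. Statements on the series, on what has been measured and on what is new or still open speak of the compounds shown alone.

Measured compounds and their values:

- Compound 1, `Cc1nc(S(C)(=O)=O)ccc1Oc1ncnc(OC2CCN(C(=O)OC(C)(C)C(F)(F)F)CC2)c1F`: 6.53 nM
- Compound 2, `Cc1nc(S(C)(=O)=O)ccc1Oc1ncnc(OC2CCN(C(=O)O[C@H](C)CF)CC2)c1F`: 196 nM
- Compound 3, `Cc1nc(S(C)(=O)=O)ccc1Oc1ncnc(OC2CCN(C(=O)OC3(C(F)(F)F)CCC3)CC2)c1F`: 14.3 nM

All three share one core and differ only in the group attached through oxygen to the carbonyl on the ring nitrogen. In a functional assay on isolated protein for inhibition of Glucose-dependent insulinotropic receptor (Homo sapiens), read by HTRF and cAMP accumulation (a higher number here means that more compound is needed for the effect, a lower number that less compound is needed), compound 3 gives 14.3 nM, the second highest of the three numbers; it sits close to compound 1, the step being a 2.2-fold higher number from compound 1 to compound 3 (0.34 log units; beyond the scatter), and far from compound 2, the step being a 14-fold lower number from compound 2 to compound 3 (1.14 log units; beyond the scatter).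

Compound 4, `Cc1nc(S(C)(=O)=O)ccc1Oc1ncnc(OC2CCN(C(=O)SC(C)C)CC2)c1F`, has not yet been measured. Compared with compound 3 the change is a group of 4 heavy atoms (3 carbon, 1 sulfur; no ring) in place of a group of 9 heavy atoms (5 carbon, 1 oxygen, 3 fluorine; one four-membered non-aromatic ring of carbon only), on a carbonyl carbon. The carbonyl thus carries a small, unbranched-ring-free group, as in compound 2. The measured steps show that the small 1-(fluoromethyl)ethyl group of compound 2 went with a much higher number than the larger fluorinated groups of compound 1 and compound 3, seen in a 30-fold higher number from compound 1 to compound 2 (1.48 log units; beyond the scatter) and a 14-fold lower number from compound 2 to compound 3 (1.14 log units; beyond the scatter). Because compound 2 gives 196 nM with its small group and the entering isopropylsulfanyl group is closer in size to that of compound 2 than to that of compound 3, compound 4 is expected to give a higher number, a step of a 14-fold higher number from compound 3 to compound 4 (1.15 log units; beyond the scatter). The estimate for compound 4 in this assay is 200 nM, with a range from 60 nM to 700 nM.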

Compound 4, half-maximal effective concentration: 6.8 nM
The estimate for compound 4 lay 29-fold (1.47 log units) above the measured number; the whole stated range lies above it.
By their numbers in this assay, from the lowest: compounds 1 and 4 (each within the scatter of the next); then compound 3; then compound 2.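

In this assay, a small group on the carbonyl carbon does not have to go with a high number: with isopropylsulfanyl there is a 29-fold lower number from compound 2 to compound 4 (1.46 log units; beyond the scatter), and also a 2.1-fold lower number from compound 3 to compound 4 (0.32 log units; beyond the scatter). Set against 1-methyl-1-(trifluoromethyl)ethoxy, the result is a 1.0-fold higher number from compound 1 to compound 4 (0.02 log units; within the scatter), so a group with no fluorine and far fewer heavy atoms reads the same as the fluorinated group of compound 1, and group size alone does not order these four compounds. Nothing available here explains why this group behaves so differently from the similarly small group of compound 2.

Going by these compounds, whether the sulfur itself matters stays open, and a direct comparison of isopropoxy with isopropylsulfanyl on this carbonyl carbon would address it. On these data alone, how an amine such as isopropylamino would read at the same place also remains unknown.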